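The source may report more compounds than this note shows. Statements on the series, on what has been measured and on what is new or still open speak of the compounds shown alone.

Measured so far, in an in vitro functional assay on HEK285-7 cells for antagonist activity at prostaglandin D2 receptor 2 (Homo sapiens), read by BRET and beta-arrestin recruitment; a lower number here means a smaller maximal response, a higher number a larger maximal response:

compound 1 `O=C(O)Cc1sc(COc2ccc(Cl)cc2)nc1-c1ccc(Cl)cc1` gives 50%
compound 2 `N#Cc1cc(-c2nc(C(c3ccc(F)cc3)c3ccc(F)cc3)sc2CC(=O)O)ccc1F` gives 80%
compound 3 `O=C(O)Cc1sc(C(c2ccc(F)cc2)c2ccc(F)cc2)nc1-c1ccncc1` gives 80%

Compound 3 stands level with compound 2 at the digits shown, and the two together are the highest of the three numbers. Compound 1 sits lower, a gap beyond the usual scatter. Within the data shown here, the only single-point change among the measured compounds is the one from compound 2 to compound 3, where pyridin-4-yl replaces 3-cyano-4-fluorophenyl on an aromatic carbon of the shared core: no change at the digits printed from compound 2 to compound 3 (within the scatter). Compound 1 differs from compound 3 in more than one place, so its value says little about any single change.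

Compound 4 `CS(=O)(=O)Nc1cccc(-c2nc(C(c3ccc(F)cc3)c3ccc(F)cc3)sc2CC(=O)O)c1` is the next compound. It differs from compound 3 at the same aromatic carbon: 3-(methanesulfonamido)phenyl in place of pyridin-4-yl on an aromatic carbon.

Among the measured compounds shown here, the one step that bears on this, the change from compound 2 to compound 3 at this position, left the maximal response unchanged within the scatter. On that basis the expected step is again none beyond the scatter: a number 2 percentage points lower from compound 3 to compound 4 (within the scatter). For compound 4 the expected value in this assay is 78%, with a range from 62% to 92%.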

Compound 4, largest response reached (reported as efficacy), in percent of the reference or control that the assay uses: 80%
Compound 4: middle estimate off by 2 percentage points, on the low side; the range from low to high includes it.
By their numbers in this assay, from the lowest: compound 1; then compounds 2, 3 and 4 (each within the scatter of the next).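

In this assay, the aromatic carbon next to the ring nitrogen has now carried three quite different groups, and the newest adds a test that the earlier pair did not provide. The 3-(methanesulfonamido)phenyl group has 11 heavy atoms against 6 for pyridin-4-yl, and it brings a sulfur, two oxygens and a hydrogen-bond donor, yet the readings show no change at the digits printed from compound 3 to compound 4 (within the scatter) and no change at the digits printed from compound 2 to compound 4 (within the scatter). Among these three compounds, then, neither swapping in this bulkier group nor adding the donor moves the maximal response beyond the scatter, and no measurement shown here explains why.

All three of these compounds share the other groups on the core, so it remains open whether the same flat result would hold with a different group on the ring atom that bears the large group. Also open, as far as these compounds go, is what a piperidin-4-yl ring with its amine, a phenyl ring carrying a carboxylic acid, or a simple methyl at this carbon would do to the maximal response.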